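This account rests on a few compounds, and the source may have more. Where it says the series, first, only, none or still open, it means among the compounds named here.

Measured compounds in an assay on isolated protein for inhibition of malate dehydrogenase, mitochondrial (Sus scrofa), with stated times of 45 min and 30 min; on this read-out higher numbers stand for weaker inhibition and lower numbers for stronger inhibition:

- compound 1 `O=S(=O)(Nc1ccc(-c2nc3ccccc3o2)cc1)c1ccccc1O` gives > 63000 nM, which is a limit of the assay and not a number.
- compound 2 `O=S(=O)(Nc1ccc2oc(-c3ccccc3)nc2c1)c1ccccc1Cl` gives > 63000 nM, likewise a limit.
- compound 3 `O=S(=O)(Nc1ccc2oc(-c3ccccc3)nc2c1)c1ccc(Cl)c(C(F)(F)F)c1` gives > 63000 nM, likewise a limit.

Within the data shown here, compound 1 therefore stands nowhere in particular among the three: every value shown sits at the limit of > 63000 nM in this assay, at which 3 of the 3 values shown sit, so no ordering between compound 1, compound 2 and compound 3 can be read from this assay, and no step between them can be sized.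

The change from compound 1 to compound 4 `CS(=O)(=O)Nc1ccc(-c2nc3ccccc3o2)cc1` is methyl in place of 2-hydroxyphenyl on a sulfonyl sulfur. Among the measured compounds shown here, because all three measured values sit at the limit of > 63000 nM in this assay, at which 3 of the 3 values shown sit, there is no measured step from which to scale an expectation; the series so far gives only limits. The working expectation is that compound 4 behaves like its neighbours, with a step that the limit leaves unreadable from compound 1 to compound 4 expected to show no movement beyond the scatter and most likely another limit. The estimate for compound 4 is 90000 nM, with a range from 30000 nM to 300000 nM, pending the actual reading.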

Compound 4, half-maximal inhibitory concentration: > 63000 nM
Compound 4 gave a limit, no number; the forecaster's own chance of this, stated with the estimate: 85%; the middle value is on the limit's open side.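

Compound 1 and compound 4 both read only as limits, so no step from compound 1 to compound 4 can be read in this assay: the limit of > 63000 nM in this assay, at which 4 of the 4 values shown sit.

The compounds shown leave open whether any change to this series gives a measurable inhibition in this assay.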